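Swapping a guanidine-bearing side chain for a methylsulfanyl one

This account rests on a few compounds, and the source may have more. Where it says the series, first, only, none or still open, it means among the compounds named here.

Measured compounds:
- compound 1, `CCCCCCCCCCCCCCCCCC(=O)N[C@@H](CCSC)C(=O)Nc1ccn([C@H]2O[C@@H](CO)[C@H](O)[C@H]2O)c(=O)n1`: 1.09
- compound 2, `CCCCCCCCCCCCCCCCCC(=O)N[C@@H](CCCNC(=N)N)C(=O)Nc1ccn([C@H]2O[C@@H](CO)[C@H](O)[C@H]2O)c(=O)n1`: 0.61
- compound 3, `CCCCCCCCCCCCCC(=O)N[C@@H](CCCNC(=N)N)C(=O)Nc1ccn([C@H]2O[C@@H](CO)[C@H](O)[C@H]2O)c(=O)n1`: 0.45

All three were tested in a physicochemical assay for lipophilicity; on this read-out higher numbers stand for higher lipophilicity and lower numbers for lower lipophilicity. Compound 2 and compound 3 share the same side chain and differ only in the length of the fatty tail: hydrogen in place of butyl on a saturated chain carbon, ten or more bonds along the chain from a carbonyl carbon. That change gave a number 0.16 log units lower from compound 2 to compound 3 (within the scatter). Compound 1 differs from compound 2 in the side chain alone: a group of 2 heavy atoms (1 carbon, 1 sulfur; no ring) in place of a group of 5 heavy atoms (2 carbon, 3 nitrogen; no ring), on a saturated chain carbon, three bonds along the chain from an amide-type nitrogen and a carbonyl carbon, which produced a number 0.48 log units higher from compound 2 to compound 1 (beyond the scatter).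

Compound 4, `CCCCCCCCCCCCCC(=O)N[C@@H](CCSC)C(=O)Nc1ccn([C@H]2O[C@@H](CO)[C@H](O)[C@H]2O)c(=O)n1`, has not yet been measured in this assay. It carries the shorter tail of compound 3 and the side chain of compound 1. The change from compound 3 to compound 4 is a group of 2 heavy atoms (1 carbon, 1 sulfur; no ring) in place of a group of 5 heavy atoms (2 carbon, 3 nitrogen; no ring), on a saturated chain carbon, three bonds along the chain from an amide-type nitrogen and a carbonyl carbon, and its place is worded identically to the change from compound 2 to compound 1, so it is the same change made on a core that differs only by the tail change given above.

Because a number 0.48 log units higher from compound 2 to compound 1 (beyond the scatter), a step of about the same size is expected here, namely a number 0.48 log units higher from compound 3 to compound 4 (beyond the scatter). Compound 4 is therefore expected to give about 0.93, with a range from 0.6 to 1.25.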

Compound 4, partition coefficient: 0.88
The estimate for compound 4 lay 0.05 log units above the measured number; low and high end bracket the measured number.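

In this assay, putting methylsulfanyl in place of the guanidine-bearing side chain on the shorter tail gave a number 0.43 log units higher from compound 3 to compound 4 (beyond the scatter) and thus a step close in size to a number 0.48 log units higher from compound 2 to compound 1 (beyond the scatter) on the longer tail, so this change carried over between these two cores. Shortening the tail with methylsulfanyl in place gave a number 0.21 log units lower from compound 1 to compound 4 (within the scatter), so that pair cannot be told apart in this measurement, and the agreement shows only that the side-chain step held across one tail change, not that it would hold on a core altered elsewhere. Nothing presented here explains why the step stayed about the same size.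

The compounds shown leave open what a side chain ending in an amine or a carboxylic acid would do on either tail. They also leave open whether the side-chain step would stay similar on a much longer chain or a much shorter one.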